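From a Thioether Chain to a Cyclobutyl Amide

The source may hold more compounds than are shown below. What is called first, only, known or untested is meant among the compounds shown, and "the series" means these compounds.

Compound 1 `CSCC(=O)N1CCN(c2nc(=O)c3cc(C(F)(F)F)cc([N+](=O)[O-])c3s2)CC1`: 15.2 ug/mL
Compound 2 `O=C(C1CC1)N1CCN(c2nc(=O)c3cc(C(F)(F)F)cc([N+](=O)[O-])c3s2)CC1`: 52.9 ug/mL

Among the compounds with values here, in a physicochemical assay for solubility, read by HPLC (on this read-out higher numbers stand for higher solubility and lower numbers for lower solubility), compound 1 stands lowest of the two numbers; the only neighbour is compound 2, reached by a 3.5-fold higher number from compound 1 to compound 2 (0.54 log units; beyond the scatter). Compound 3 `O=C(C1CCC1)N1CCN(c2nc(=O)c3cc(C(F)(F)F)cc([N+](=O)[O-])c3s2)CC1` is not yet measured. (cyclobutyl in place of (methylsulfanyl)methyl on a carbonyl carbon). Within the data shown here, the single step that bears on this change is a 3.5-fold higher number from compound 1 to compound 2 (0.54 log units; beyond the scatter), a modest rise on going to the three-membered ring. A four-membered ring is expected to behave alike, so an upward step a 2.0-fold higher number from compound 1 to compound 3 (0.30 log units; within the scatter) is estimated, and compound 3 is expected to give 30 ug/mL in this assay, within 10 ug/mL to 80 ug/mL.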

Compound 3, solubility: 39.3 ug/mL
Estimate against measurement, compound 3: 1.3-fold (0.12 log units) below; the range from low to high includes it.
By their numbers in this assay, from the lowest: compound 1; then compounds 3 and 2 (each within the scatter of the next).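

In this assay, the rise on leaving the (methylsulfanyl)methyl group at this carbonyl carbon is not confined to cyclopropyl, since cyclobutyl also gives one (a 2.6-fold higher number from compound 1 to compound 3 (0.41 log units; beyond the scatter)). Cyclobutyl and cyclopropyl cannot be told apart here (a 1.3-fold lower number from compound 2 to compound 3 (0.13 log units; within the scatter)). Nothing in hand explains either step. The compounds shown leave open whether sulfur or the ring matters, as an open carbon chain such as isobutyl would test. They also leave open how a ring containing oxygen, such as oxetanyl, or a larger ring such as cyclohexyl would read at this carbonyl carbon.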